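Chloro in Place of Hydrogen on an Inactive Scaffold

This account rests on a few compounds, and the source may have more. Where it says the series, first, only, none or still open, it means among the compounds named here.

Compound 1 `COc1ccc(-c2noc(-c3ccccc3)n2)cc1OC1CCCC1` was tested in a functional assay on MDA-MB-231 cells (Homo sapiens) for antiproliferative activity, read by MTT assay, with a stated time of 24 h; on this read-out lower numbers stand for stronger inhibition and higher numbers for weaker inhibition. In this assay compound 1 gives > 1000000 nM, which is a limit of the assay rather than a number. Compound 2 `COc1ccc(-c2noc(-c3ccc(F)cc3)n2)cc1O` also reaches only a limit in this assay, > 1000000 nM. Compound 1 thus stands at the limit of > 1000000 nM in this assay, at which 2 of the 2 values shown sit, and nothing in the numbers sets it apart from compound 2. Compound 3 `COc1ccc(-c2noc(-c3ccc(Cl)cc3)n2)cc1OC1CCCC1` is the next to be tested. It differs from compound 1 in one place: chloro in place of hydrogen on an aromatic carbon. Going by the values given here, no step between measured compounds shows what such a change does here, and both measured values are limits, so there is no measured inhibition to build on. The step of a number no higher from compound 1 to compound 3 (the limit leaves the size open) is expected to be none beyond the scatter. Compound 3 is therefore expected to give about 1000000 nM, within 200000 nM to 5000000 nM, most likely again as a limit.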

Compound 3, half-maximal inhibitory concentration: 396000 nM
Compound 3: middle estimate off by 2.5-fold (0.40 log units), on the high side; low and high end bracket the measured number.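

In this assay, chloro in place of hydrogen on an aromatic carbon, para to a large group, gives an at least 2.5-fold lower number from compound 1 to compound 3 (0.40 log units; beyond the scatter). From the compounds shown here alone, compound 1 gives > 1000000 nM, which is a limit and not a number, so the real size of this step stays unknown. Even so, this is the first sign that the scaffold can produce a measurable effect in this assay and that this ring position responds to a change, although compound 3 still needs a high concentration, 396000 nM.

Going by these compounds, whether an amine or a carboxylic acid at this same place would lower the number further, or raise it, remains open. Few comparisons are possible so far, and most of the series still gives no exact number: the limit of > 1000000 nM in this assay, at which 2 of the 3 values shown sit.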